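The source may report more compounds than this note shows. Statements on the series, on what has been measured and on what is new or still open speak of the compounds shown alone.

Four compounds built on one shared core are compared in a physicochemical assay (Homo sapiens) for solubility, with a stated time of 18 h, at pH 7.4; on this read-out higher numbers stand for higher solubility and lower numbers for lower solubility. Compound 1, `CN1CCN(c2ccc(/C=C3/SC(Nc4ccccc4Cl)=NC3=O)cc2)CC1`, gives 0.43 ug/mL in this assay. Compound 2, `O=C1N=C(Nc2ccccc2Cl)S/C1=C/c1ccc(N2CCNCC2)cc1`, gives 0.14 ug/mL in this assay, and the step between them, a 3.1-fold lower number from compound 1 to compound 2 (0.49 log units; beyond the scatter), is the change (hydrogen in place of methyl on an amine nitrogen in a ring). Compound 3, `Cc1ccccc1NC1=NC(=O)/C(=C\c2ccc(N3CCN(C)CC3)cc2)S1`, gives 0.89 ug/mL in this assay; it differs from compound 1 by methyl in place of chloro on an aromatic carbon, and that step is a 2.1-fold higher number from compound 1 to compound 3 (0.32 log units; beyond the scatter), leaving compound 3 with the highest of the three measured numbers.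

Compound 4, `Cc1ccccc1NC1=NC(=O)/C(=C\c2ccc(N3CCNCC3)cc2)S1`, is not yet measured in this assay. It differs from compound 3 by hydrogen in place of methyl on an amine nitrogen in a ring. This is the same change that was made from compound 1 to compound 2, occurring twice in all among these compounds, now set on the core of compound 3 rather than on the core of compound 1; the cores themselves differ by methyl in place of chloro on an aromatic carbon.

Among the measured compounds shown here, the step expected from compound 3 to compound 4 in this assay is a 3.1-fold lower number from compound 3 to compound 4 (0.49 log units; beyond the scatter), resting on the single earlier instance, a 3.1-fold lower number from compound 1 to compound 2 (0.49 log units; beyond the scatter). Compound 4 is therefore estimated at 0.29 ug/mL, with an expected range from 0.12 ug/mL to 0.7 ug/mL.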

Compound 4, solubility: 3.83 ug/mL
For compound 4 the middle estimate is 13-fold (1.12 log units) below the measured one; measured number above the stated range.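

In this assay the change from 4-methylpiperazin-1-yl to piperazin-1-yl gives a 4.3-fold higher number from compound 3 to compound 4 (0.63 log units; beyond the scatter) on the core of compound 3, whereas on the core of compound 1 it gave a 3.1-fold lower number from compound 1 to compound 2 (0.49 log units; beyond the scatter) and so the step does not carry over between these cores, even in direction. The companion change, methyl in place of chloro on an aromatic carbon, also differs with its setting, giving a 2.1-fold higher number from compound 1 to compound 3 (0.32 log units; beyond the scatter) when 4-methylpiperazin-1-yl is present and a 27-fold higher number from compound 2 to compound 4 (1.44 log units; beyond the scatter) when piperazin-1-yl is present. These two pairs show that the two changes do not act independently here, but they set no rule for any other core, and nothing available accounts for the reversal.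

As far as these compounds go, it remains open whether the reversal persists when fluoro or methoxy stands on that aromatic carbon instead of chloro or methyl. From the compounds shown here alone, it is equally open how an ethyl or acetyl group on the ring nitrogen would compare with hydrogen and methyl on these cores.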